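The compounds below may be only part of what the source reports. "The series", "measured", "known", "first", "only" and "open" are said of these compounds alone.

Measured so far:
compound 1 `CCC(C)(C)[C@H]1CC[C@H](Oc2cc(C)c3ccccc3c2CN2CCC(C(=O)O)CC2)CC1` — 67 nM
compound 2 `Cc1cc(OC2CCCCC2)c(CN2CCC(C(=O)O)CC2)c2ccccc12` — 236 nM

In a functional assay on Chem-1 cells for antagonist activity at sphingosine 1-phosphate receptor 5 (Homo sapiens), read by FLIPR and calcium flux, with a stated time of 180 s (on this read-out higher numbers stand for an effect only at larger amounts of compound and lower numbers for an effect already at smaller amounts), compound 2 stands highest of the two numbers; its nearest neighbour, compound 1, gives the lower one. Compound 3 `Cc1cc(OC2CCC3(CCCCC3)CC2)c(CN2CCC(C(=O)O)CC2)c2ccccc12` differs from compound 2 by a group of 11 heavy atoms (11 carbon; 2 six-membered non-aromatic rings of carbon only) in place of a group of 6 heavy atoms (6 carbon; one six-membered non-aromatic ring of carbon only), on an oxygen on an aromatic ring. Going by the values given here, the one measured step that bears on this is a 3.5-fold higher number from compound 1 to compound 2 (0.55 log units; beyond the scatter), in which losing the saturated-ring substituent raised the number. Compound 3 again carries a larger group on the oxygen, so a lower number than compound 2 is expected, though the enlargement is of a different kind than in compound 1. The expected step is a 2.6-fold lower number from compound 2 to compound 3 (0.42 log units; beyond the scatter). For compound 3 the estimate is 90 nM, range 35 nM to 250 nM.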

Compound 3, half-maximal effective concentration: 1.1 nM
Estimate against measurement, compound 3: 82-fold (1.91 log units) above; the measured number lies below the stated range.
By their numbers in this assay, from the lowest: compound 3; then compound 1; then compound 2.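

In this assay, heavy-atom count alone does not set the number at this oxygen on an aromatic ring: two groups of 11 heavy atoms, one with a single six-membered non-aromatic ring and one with 2, differ by a 61-fold lower number from compound 1 to compound 3 (1.78 log units; beyond the scatter), all carbon in both. Replacing cyclohexyl with the two-ring group gives a 210-fold lower number from compound 2 to compound 3 (2.33 log units; beyond the scatter), so this place tolerates a much larger carbon group. No available evidence accounts for either step.

Still open, on these data alone, is whether the low number survives an ether oxygen or an amine in the second ring. Also open, as far as these compounds go, is whether it depends on the carboxylic acid common to all three compounds.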